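This account rests on a few compounds, and the source may have more. Where it says the series, first, only, none or still open, it means among the compounds named here.

Measured compounds in an assay on HEK-293T cells for displacement of a labelled ligand from corticotropin-releasing factor receptor 1 (Homo sapiens), read by scintillation counting, with a stated time of 2 h; on this read-out higher numbers stand for weaker inhibition and lower numbers for stronger inhibition:
- compound 1 `CCCCN(CC)c1cc(C)nc2c1NC(=O)CN2c1ccc(C)cc1Cl` gives 4.4 nM
- compound 2 `CCCCN(CC)c1cc(C)nc2c1NC(=O)CN2c1ccc(Br)cc1Br` gives 1.3 nM
- compound 3 `CCCCN(CC)c1cc(C)nc2c1NC(=O)CN2c1ccc(C)cc1Br` gives 4.4 nM

Compound 3 sits level with compound 1; together they give the highest numbers of the three, and the step of no change at the digits printed from compound 1 to compound 3 (within the scatter) is within the scatter. Compound 2 stands apart from both, as the step of a 3.4-fold higher number from compound 2 to compound 3 (0.53 log units; beyond the scatter) shows a modest gain in the other direction, and a 3.4-fold lower number from compound 1 to compound 2 (0.53 log units; beyond the scatter) matches it.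

The next compound, compound 4 `CCCCN(CC)c1cc(C)nc2c1NC(=O)CN2c1ccc(OC)cc1C`, is not yet measured. It differs from compound 3 as follows: 4-methoxy-2-methylphenyl in place of 2-bromo-4-methylphenyl on a nitrogen on an aromatic ring in a ring. The measured steps touch only part of this change. Exchange of bromo for chloro, no change at the digits printed from compound 1 to compound 3 (within the scatter), left the number unchanged; exchange of methyl for bromo, a 3.4-fold higher number from compound 2 to compound 3 (0.53 log units; beyond the scatter), cost a modest amount. For the measured compounds named here, no measured step covers a methoxy group or the 4-methoxy-2-methylphenyl as a whole, so the bearing of these steps is indirect. A step of about the size seen between compound 2 and compound 3 is expected, in the direction of a higher number, though a result within the scatter of compound 3 cannot be ruled out. The expected step is a 2.3-fold higher number from compound 3 to compound 4 (0.36 log units; beyond the scatter). Compound 4 is estimated at 10 nM, with a range from 3 nM to 35 nM.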

Compound 4, inhibition constant: 4 nM
For compound 4 the middle estimate is 2.5-fold (0.40 log units) above the measured one; the measured number falls inside the stated range.
By their numbers in this assay, from the lowest: compound 2; then compounds 4, 1 and 3 (each within the scatter of the next).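

In this assay, the first aryl group without a halogen holds its place: 4-methoxy-2-methylphenyl in place of 2-bromo-4-methylphenyl gives a 1.1-fold lower number from compound 3 to compound 4 (0.04 log units; within the scatter) and the same group in place of 2-chloro-4-methylphenyl gives a 1.1-fold lower number from compound 1 to compound 4 (0.04 log units; within the scatter), so among these compounds a halogen on this ring is not required to stay level with compounds 1 and 3, and a group with a hydrogen-bond acceptor is accepted at this place. Only the 2,4-dibromophenyl group stands apart, with a 3.1-fold higher number from compound 2 to compound 4 (0.49 log units; beyond the scatter) adding a third step beyond the scatter that separates compound 2 from the other three compounds. No supporting data are available to explain why these aryl groups match or why the dibromo compound differs.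

The step from compound 3 to compound 4 alters two sites on the aryl ring at once, so the compounds shown cannot say whether the two exchanges are each silent or offset one another, and 2-bromo-4-methoxyphenyl would separate them. Also open, as far as these compounds go, is how this position responds to a larger or charged substituent on the ring, such as an amine, a carboxylic acid or a longer alkoxy chain.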